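The compounds below may be only part of what the source reports. "The series", "measured", "known", "first", "only" and "open" are said of these compounds alone.

In an assay on CHO cells for antagonist activity at transient receptor potential cation channel subfamily V member 1 (Homo sapiens), read by FLIPR (on this read-out higher numbers stand for weaker inhibition and lower numbers for stronger inhibition), three compounds have been measured:

compound 1 `CC(C(=O)NCc1ccc(C(F)(F)F)cc1N1CCC(c2ccc(F)cc2)CC1)c1ccc(NS(C)(=O)=O)c(F)c1`: 0.9 nM
compound 2 `Cc1ccc(N2CCN(c3cc(C(F)(F)F)ccc3CNC(=O)C(C)c3ccc(NS(C)(=O)=O)c(F)c3)CC2)cc1`: 0.7 nM
compound 3 `CC(C(=O)NCc1ccc(C(F)(F)F)cc1OC1CCCC1)c1ccc(NS(C)(=O)=O)c(F)c1`: 0.6 nM

The three numbers sit close together, and the gaps from compound 3 to compound 2 and to compound 1 both lie within the usual scatter, so none of the three can be set apart from the others on these numbers. Compound 4 `CC(C(=O)NCc1ccc(C(F)(F)F)cc1-c1ccc(C(C)(C)C)cc1)c1ccc(NS(C)(=O)=O)c(F)c1` differs from compound 3 in one place: 4-(tert-butyl)phenyl in place of cyclopentyloxy on an aromatic carbon. Among the compounds with values here, no step between measured compounds isolates this kind of change, so the expectation rests on the fact that the shared core tolerates varied groups at this position in compounds 1, 2 and 3. The step from compound 3 to compound 4 is expected to be small, a 2.5-fold higher number from compound 3 to compound 4 (0.40 log units; beyond the scatter), most likely within the scatter. Compound 4 is therefore estimated at 1.5 nM, between 0.4 nM and 6 nM.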

Compound 4, inhibition constant: 1.1 nM
Compound 4: the middle estimate sits 1.4-fold (0.13 log units) above what was measured; measured number inside the range.
By their numbers in this assay, from the lowest: compounds 3, 2, 1 and 4 (each within the scatter of the next).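

In this assay, the change from cyclopentyloxy to 4-(tert-butyl)phenyl gives a 1.8-fold higher number from compound 3 to compound 4 (0.26 log units; within the scatter) and so makes no clear difference. This position on the shared core therefore accepts an aromatic ring of carbon only, without the oxygen link and its hydrogen-bond acceptor, and the number stays in the same range. No measurement here explains why the numbers stay so close.

Still open, on these data alone, is whether a carboxylic acid or a primary amine at this position would fit as well. A short group such as methoxy poses the same open question.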